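Opening a spiro amide toward a sulfonamide chain

The source may report more compounds than this note shows. Statements on the series, on what has been measured and on what is new or still open speak of the compounds shown alone.

Measured compounds:
compound 1 `CC(C)(C)c1ccc(C(=O)N2CCC3(CC2)C(=O)N(CC(=O)N2CCC(CCO)CC2)CN3c2ccccc2)cc1` — 2600 nM
compound 2 `CC(C)(C)OC(=O)NC1CCN(C(=O)CN2CN(c3ccccc3)C3(CCN(C(=O)c4ccc(C(C)(C)C)cc4)CC3)C2=O)CC1` — 8300 nM
compound 3 `CCC1CCCN(C(=O)CN2CN(c3ccccc3)C3(CCN(C(=O)c4ccc(C5CCCCC5)cc4)CC3)C2=O)C1` — 2600 nM

In an assay on HEK293 cells for displacement of a labelled ligand from NPC1-like intracellular cholesterol transporter 1 (Homo sapiens) (a higher number here means a weaker inhibitor, a lower number a stronger inhibitor), compound 1 stands level with compound 3 at the digits shown, and the two together give the lowest numbers of the three; compound 2 lies furthest away, as the step of a 3.2-fold higher number from compound 1 to compound 2 (0.50 log units; beyond the scatter) records. Compound 4 `CC(C)(C)c1ccc(C(=O)N2CCC3(CC2)C(=O)N(CC(=O)NCCCCCNS(C)(=O)=O)CN3c2ccccc2)cc1` differs from compound 1 in one place: (5-(methanesulfonamido)pentyl)amino in place of 4-(2-hydroxyethyl)piperidin-1-yl on a carbonyl carbon. For the measured compounds named here, the only measured step that touches this part of the molecule is a 3.2-fold higher number from compound 1 to compound 2 (0.50 log units; beyond the scatter), where an exchange on the saturated ring gave a modest rise. The present change goes further, replacing the whole ring with an open chain, so a rise in this assay is expected for compound 4, estimated as a 2.1-fold higher number from compound 1 to compound 4 (0.33 log units; beyond the scatter). Compound 4 is therefore expected to give about 5500 nM, within 1800 nM to 17000 nM.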

Compound 4, half-maximal inhibitory concentration: 5500 nM
The estimate for compound 4 equals the measured number at the digits printed, and the stated range covers the measured number.
By their numbers in this assay, from the lowest: compounds 1 and 3 (each within the scatter of the next); then compounds 4 and 2 (each within the scatter of the next).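

In this assay the place on the carbonyl carbon accepts an open chain: (5-(methanesulfonamido)pentyl)amino in place of 4-(2-hydroxyethyl)piperidin-1-yl costs only a modest step (a 2.1-fold higher number from compound 1 to compound 4 (0.33 log units; beyond the scatter)). For the compounds shown here, the earlier compounds all carried a saturated ring here, so compound 4 is the first to show that this ring can be given up. No evidence at hand explains the size of this step. On these data alone, whether the step follows from losing the ring or from the methanesulfonamide remains open. A pentyl chain ending in a hydroxyl or an amine, or a longer chain, could separate the two.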